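Pyrrole series: aryl groups in place of ethoxycarbonyl

The compounds below may be only part of what the source reports. "The series", "measured", "known", "first", "only" and "open" are said of these compounds alone.

Three compounds of the shared core have numbers in an assay for inhibition of 3-hydroxy-3-methylglutaryl-coenzyme A reductase (Rattus norvegicus); on this read-out lower numbers stand for stronger inhibition and higher numbers for weaker inhibition. Compound 1 `CCOC(=O)c1c(-c2ccccc2)c(-c2ccccc2)n(CC[C@@H]2C[C@@H](O)CC(=O)O2)c1CC` gives 890 nM. Compound 2 `CCOC(=O)c1c(C(=O)OCC)c(C(C)C)n(CC[C@@H]2C[C@@H](O)CC(=O)O2)c1-c1ccc(F)cc1` gives 350 nM; compound 3 `CCOC(=O)c1c(-c2ccccc2)c(C(C)C)n(CC[C@@H]2C[C@@H](O)CC(=O)O2)c1-c1ccc(F)cc1` gives 50 nM. Compound 2 thus stands second highest of the three, nearer to compound 1 than to compound 3. Compound 4 `CCOC(=O)c1c(-c2ccc(C#N)cc2)c(-c2ccc(F)cc2)n(CC[C@@H]2C[C@@H](O)CC(=O)O2)c1C(C)C` is not yet measured; it differs from compound 2 by 4-cyanophenyl in place of ethoxycarbonyl on an aromatic carbon. Among the measured compounds shown here, the one step that bears on this is the exchange of the same ethoxycarbonyl for phenyl, a 7.0-fold lower number from compound 2 to compound 3 (0.85 log units; beyond the scatter), well beyond the scatter. A similar aryl group is entering here, so a step of comparable size and the same direction is expected, a 5.8-fold lower number from compound 2 to compound 4 (0.77 log units; beyond the scatter). For compound 4 the number in this assay is estimated at 60 nM, with a range from 20 nM to 200 nM.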

Compound 4, half-maximal inhibitory concentration: 280 nM
Estimate against measurement, compound 4: 4.7-fold (0.67 log units) below; the whole stated range lies below it.
By their numbers in this assay, from the lowest: compound 3; then compounds 4 and 2 (each within the scatter of the next); then compound 1.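

In this assay, 4-cyanophenyl in place of ethoxycarbonyl on the carbon next to the ring atom that bears a 4-fluorophenyl group gives no separation from the ester, a 1.3-fold lower number from compound 2 to compound 4 (0.10 log units; within the scatter). This differs from a 7.0-fold lower number from compound 2 to compound 3 (0.85 log units; beyond the scatter), but in compound 3 this carbon keeps its ethoxycarbonyl, so the two steps differ in both the entering group and the carbon replaced. No evidence is available to explain the contrast. Open, from the compounds shown here alone, is whether an unsubstituted phenyl on this carbon would match compound 4, and how an amine or a carboxylic acid in place of the nitrile would read.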